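The source may report more compounds than this note shows. Statements on the series, on what has been measured and on what is new or still open speak of the compounds shown alone.

Compound 1 `COc1ccccc1-n1cc(COc2c(/C=C\C(=O)O)ccc(OC)c2CC=C(C)C)nn1`, one member of a small set of compounds built on a shared core, gives 12200 nM in a functional assay on COLO 205 cells (Homo sapiens) for cytotoxicity, read by MTT assay, with a stated time of 24 h; a higher number here means a weaker inhibitor, a lower number a stronger inhibitor. Its closest neighbour, compound 2 `COc1ccc(/C=C\C(=O)O)c(OCc2cn(-c3ccc(NC(=O)c4ccccc4)cc3)nn2)c1CC=C(C)C`, carries a benzamide on the benzene ring in place of the methoxy group; in this assay compound 2 gives 20300 nM, and the gap between the two numbers is within the usual scatter, so the two cannot be ranked against each other. A third member, compound 3 `COc1cccc(-n2cc(COc3c(/C=C\C(=O)O)ccc(OC)c3CC=C(C)C)nn2)c1`, moves the methoxy group to another position on the same ring; in this assay compound 3 gives "not determined" (no result reported), so no number is available for it.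

Compound 4 `COc1ccc(/C=C\C(=O)O)c(OCc2cn(-c3ccccc3)nn2)c1CC=C(C)C` is the next compound to be examined. It differs from compound 1 in one place only: hydrogen in place of methoxy on an aromatic carbon. The step that is expected, a 1.1-fold higher number from compound 1 to compound 4 (0.06 log units; within the scatter), stays within the scatter because compound 1 gives 12200 nM and compound 2 gives 20300 nM, two numbers that lie within the scatter of each other. On that basis compound 4 is estimated to give 14000 nM in this assay, with a plausible range from 6000 nM to 35000 nM.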

Compound 4, half-maximal inhibitory concentration: 32300 nM
Compound 4: the middle estimate sits 2.3-fold (0.36 log units) below what was measured; measured number inside the range.
By their numbers in this assay, from the lowest: compounds 1, 2 and 4 (each within the scatter of the next, the first and the last beyond it).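

Taking the methoxy group away from the ring, the change from 2-methoxyphenyl to phenyl, gives in this assay a 2.6-fold higher number from compound 1 to compound 4 (0.42 log units; beyond the scatter) and is the first step in this small set that can be read, so this carbon, ortho to a large group, is a place where a small substituent can shift the number, though only modestly, with the methoxy compound the stronger of the two. The other step, with hydrogen in place of benzamido, gives a 1.6-fold higher number from compound 2 to compound 4 (0.20 log units; within the scatter) and so shows no difference that can be trusted, which means that a small methoxy group and a much larger benzamido group on this ring cannot be told apart from each other or, in the second case, from hydrogen. Nothing measured here accounts for the methoxy step.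

As far as these compounds go, whether another small group on this carbon, such as a fluorine atom, a hydroxyl or an amine, would match the methoxy group remains open. Also open, from the compounds shown here alone, is whether the methoxy group still counts at another position on the same ring, since compound 3 offers no number to compare.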